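Fluoroalkoxy chain length and a drawn stereocentre

A few compounds are considered here, and "the series" means these few. Any claim that something is new, unique, unknown or untested is made for them only; others in the source may bear on it.

Of the compounds shown here, three sharing one core have been measured in an assay on HEK293 cells for displacement of a labelled ligand from Neuronal acetylcholine receptor; alpha4/beta2 (Homo sapiens), read by scintillation counting, with a stated time of 120 min; on this read-out lower numbers stand for stronger inhibition and higher numbers for weaker inhibition. Compound 1 `FCCOc1cccc(-c2cn(C3CN4CCC3CC4)nn2)c1` gives 1960 nM, compound 2 `FCCCOc1cccc(-c2cn([C@@H]3CN4CCC3CC4)nn2)c1` gives 1980 nM, and compound 3 `FCCCOc1cccc(-c2cn(C3CN4CCC3CC4)nn2)c1` gives 3890 nM in this assay.

Two measured compounds differ in one place. Going from compound 3 to compound 1, the structural change is fluoro in place of fluoromethyl on a saturated chain carbon, two bonds along the chain from an oxygen on an aromatic ring, and this assay shows a 2.0-fold lower number from compound 3 to compound 1 (0.30 log units; within the scatter). Compound 2 and compound 3 differ only in how they are drawn (the two compounds have the same atoms and bonds; at least one stereo element is drawn with a configuration in one of them and without one in the other: 1 of 3 stereo elements differ; a stereocentre at a saturated ring carbon is drawn without a configuration in compound 3 and S in compound 2); this assay shows a 2.0-fold higher number from compound 2 to compound 3 (0.29 log units; within the scatter), a step that may rest on (the fact that one of compounds 2 and 3 is drawn with a defined configuration and the other without, at the place where they differ).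

Compound 4 `FCCOc1cccc(-c2cn([C@@H]3CN4CCC3CC4)nn2)c1` has not yet been measured in this assay. It differs from compound 2 in the same way that compound 1 differs from compound 3: fluoro in place of fluoromethyl (fluoro in place of fluoromethyl on a saturated chain carbon, two bonds along the chain from an oxygen on an aromatic ring), at the same place. Compound 4 is expected to follow the step seen from compound 3 to compound 1 a 2.0-fold lower number from compound 3 to compound 1 (0.30 log units; within the scatter), giving a 1.8-fold lower number from compound 2 to compound 4 (0.26 log units; within the scatter) in this assay. Going by the values given here, compound 4 is therefore estimated at 1100 nM in this assay, with a likely range from 400 nM to 3000 nM, since the single measured example of this change lies within the scatter.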

Compound 4, inhibition constant: 1260 nM
Estimate against measurement, compound 4: 1.1-fold (0.06 log units) below; measured number inside the range.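

Replacing 3-fluoropropoxy with 2-fluoroethoxy on the core with its stereocentre drawn S gives a 1.6-fold lower number from compound 2 to compound 4 (0.20 log units; within the scatter) in this assay, and this step agrees with the earlier one on the core drawn without a configuration: the same change on two cores in this assay, a 2.0-fold lower number (0.30 log units; within the scatter) from compound 3 to compound 1 and a 1.6-fold lower number (0.20 log units; within the scatter) from compound 2 to compound 4, 1.3-fold (0.10 log units) apart, within the scatter of two such steps. The change therefore reads alike in these two pairs, but each step lies within the usual scatter of repeated measurements, so the data do not show that either chain length truly gives stronger inhibition, and two pairs are too few to support a rule for the series. The two cores are also very close, and a 1.6-fold lower number from compound 1 to compound 4 (0.19 log units; within the scatter) is again within the scatter, so this is a test across a single drawn stereocentre and not across truly different cores, with the pair separated only by this: the fact that one of compounds 1 and 4 is drawn with a defined configuration and the other without, at the place where they differ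

The compounds shown leave open whether the same reading would hold on a core with different atoms and how the centre drawn with the opposite configuration would compare. They also leave open what a longer fluoroalkoxy chain, or a plain ethoxy group without fluorine, would give at the same place.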